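The compounds below may be only part of what the source reports. "The series", "measured", "known", "first", "only" and "open" are said of these compounds alone.

Compound 1 `O=C(CSC(=S)N[C@H]1CCOC1=O)Nc1ccccc1` and compound 2 `O=C(CSC(=S)N[C@H]1CCOC1=O)Nc1ccccc1Cl` share one core, while compound 3 `O=C(CCl)Nc1ccc(C(=O)/C=C/c2ccc(Cl)cc2)cc1` is built on a different one; the difference between the two cores is not broken down here. In a functional assay on MGC-803 cells (Homo sapiens) for cytotoxicity, read by MTT assay, with a stated time of 72 h (on this read-out higher numbers stand for weaker inhibition and lower numbers for stronger inhibition), compound 1 gives 39700 nM, and compound 2 gives 32000 nM. These two are related by a single change, (hydrogen in place of chloro on an aromatic carbon), which made a step of a 1.2-fold higher number from compound 2 to compound 1 (0.09 log units; within the scatter). Compound 3 gives 4960 nM in this assay, the lowest of the three numbers. Compound 4 `O=C(CCl)Nc1ccc(C(=O)/C=C/c2ccccc2)cc1` has not yet been measured in this assay; it arises from compound 3 by the change (hydrogen in place of chloro on an aromatic carbon). Here the chloro that leaves sits para to a large group, whereas in the earlier pair it sat ortho to a large group, so this is the same kind of change, not the same change. Because compound 2 and compound 1 differ only by a 1.2-fold higher number from compound 2 to compound 1 (0.09 log units; within the scatter), the expected step is a 1.1-fold higher number from compound 3 to compound 4 (0.04 log units; within the scatter). The estimate for compound 4 in this assay is 5500 nM, expected to fall between 2500 nM and 12000 nM.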

Compound 4, half-maximal inhibitory concentration: 6940 nM
Beside the measured number, compound 4's estimate is 1.3-fold (0.10 log units) below it; the range from low to high includes it.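

In this assay, replacing the chloro with hydrogen gives a step of a 1.4-fold higher number from compound 3 to compound 4 (0.15 log units; within the scatter), and this result agrees with the same kind of change on the other core: the same change on two cores in this assay, a 1.2-fold higher number (0.09 log units; within the scatter) from compound 2 to compound 1 and a 1.4-fold higher number (0.15 log units; within the scatter) from compound 3 to compound 4, 1.1-fold (0.05 log units) apart, within the scatter of two such steps On these two cores, then, removing the aromatic chloro changes the number by no more than repeated measurements would be expected to vary, so in both pairs the change makes no clear difference. This does not give the change a reliable size or direction, since both steps are too small to separate from scatter, and two pairs cannot show that the same would hold on a third core or in a different assay.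

The compounds shown leave open whether a different group in that place, such as a methoxy group, an amine or a carboxylic acid, would produce a step beyond the scatter. They also leave open whether a bromo group would behave like the chloro on either core.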